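Changing the amide substituent on a shared core

A few compounds are considered here, and "the series" means these few. Any claim that something is new, unique, unknown or untested is made for them only; others in the source may bear on it.

Measured in a functional assay on the whole organism with Mus musculus as the target; a higher number here means that more compound is needed for the effect, a lower number that less compound is needed:
Compound 1 `O=C(Cn1c(-c2ccc(Cl)cc2)nc2cccnc21)N1CCCCC1`: 56.2 mg/kg
Compound 2 `O=C(Cn1c(-c2ccc(Cl)cc2)nc2cccnc21)Nc1ccccn1`: 100 mg/kg

Compound 2, at 100 mg/kg, lies within the scatter of compound 1. Compound 3 `CCOC(=O)CCCNC(=O)Cn1c(-c2ccc(Cl)cc2)nc2cccnc21` keeps the shared core and differs from compound 2 at one place: 3-(ethoxycarbonyl)propyl in place of pyridin-2-yl on an amide-type nitrogen. Thus 3-(ethoxycarbonyl)propyl stands in place of pyridin-2-yl on an amide-type nitrogen. Among the measured compounds shown here, one measured step bears on this, also a change of the amide substituent: a 1.8-fold higher number from compound 1 to compound 2 (0.25 log units; within the scatter). From this single step, no change beyond the scatter is expected in this assay, and no direction can be favoured. The estimated step is a 1.4-fold lower number from compound 2 to compound 3 (0.15 log units; within the scatter). Compound 3 is expected at 70 mg/kg, with an estimated range of 30 mg/kg to 160 mg/kg.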

Compound 3, dose for half-maximal effect: 100 mg/kg
Compound 3: middle estimate off by 1.4-fold (0.15 log units), on the low side; low and high end bracket the measured number.
By their numbers in this assay, from the lowest: compounds 1, 2 and 3 (each within the scatter of the next).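

In this assay, 3-(ethoxycarbonyl)propyl, which has no ring, in place of pyridin-2-yl on the amide-type nitrogen gives no change at the digits printed from compound 2 to compound 3 (within the scatter). Set against piperidin-1-yl on the carbonyl carbon, (3-(ethoxycarbonyl)propyl)amino gives a 1.8-fold higher number from compound 1 to compound 3 (0.25 log units; within the scatter), so all three amide substituents shown, with or without a ring, lie within the scatter of one another. Nothing available accounts for this result.

As far as these compounds go, it remains open whether a carboxylic acid at the end of the chain in place of the ethyl ester, or a terminal amine, would give a step beyond the scatter.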